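Cyclopentyl for Methyl on the Shared Core

This account rests on a few compounds, and the source may have more. Where it says the series, first, only, none or still open, it means among the compounds named here.

Compound 1, `C[C@H](NC(=O)c1c(C(F)(F)F)nnn1Cc1cccc(C(F)(F)F)c1)c1ccc(C(=O)O)cc1`: in a functional assay on CHO cells for antagonist activity at prostaglandin E2 receptor EP4 subtype (Homo sapiens), read by calcium flux, with a stated time of 15 min (a higher number here means a weaker inhibitor, a lower number a stronger inhibitor), compound 1 gives 1970 nM
Compound 2, `Cc1nnn(Cc2ccc(C(F)(F)F)cc2)c1C(=O)N[C@@H](C)c1ccc(C(=O)O)cc1`: in this assay compound 2 gives > 10000 nM
Compound 3, `COc1ccc(Cn2nnc(-c3ccccc3)c2C(=O)N[C@@H](C)c2ccc(C(=O)O)cc2)cc1F`: in this assay compound 3 gives 29.8 nM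

The value for compound 2 is a limit of the assay rather than a number, so its position among the three is known only in this way (the limit of > 10000 nM in this assay, at which 1 of the 3 values shown sits). Among the compounds with values here, compound 1 and compound 3 carry different groups on the same aromatic carbon and different benzyl groups, and their values differ widely; since none of these pairs differs in one place only, no single step between them can be read.

Compound 4, `C[C@H](NC(=O)c1c(C2CCCC2)nnn1Cc1ccc(C(F)(F)F)cc1)c1ccc(C(=O)O)cc1`, is not yet measured. It comes from compound 2 by one change: cyclopentyl in place of methyl on an aromatic carbon. The measured compounds suggest that a larger group at this place goes with stronger inhibition, compound 3 with phenyl there giving 29.8 nM, though compound 3 also differs elsewhere. Compound 4 is therefore expected to be a stronger inhibitor than compound 2, with a step of an at least 25-fold lower number from compound 2 to compound 4 (1.39 log units; beyond the scatter) expected. Compound 4 is estimated at 400 nM, within a range from 60 nM to 4000 nM.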

Compound 4, half-maximal inhibitory concentration: 65.1 nM
Compound 4: middle estimate off by 6.1-fold (0.79 log units), on the high side; low and high end bracket the measured number.
By their numbers in this assay, from the lowest: compound 3; then compound 4; then compound 1. At a limit, above all of these: compound 2.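

Within the data shown here, this is the first step that can be read at a single place: on an aromatic carbon of a five-membered aromatic ring with 3 nitrogen, with all else held fixed, cyclopentyl in place of methyl gives an at least 150-fold lower number from compound 2 to compound 4 (2.18 log units; beyond the scatter) in this assay. Among these compounds, this carbon is therefore a place where the group alone can move the number far beyond the scatter, which compound 1 and compound 3 could not show, as no pair among the earlier compounds differs in one place only. The value for compound 2 is a limit and not a number, so the step carries that limit with it: the limit of > 10000 nM in this assay, at which 1 of the 4 values shown sits.

Still open, from the compounds shown here alone, is whether the step follows from the ring itself or simply from the extra carbons, a question that an open chain such as isopropyl or a smaller ring such as cyclopropyl could address at this carbon with the same benzyl group. Also open, going by these compounds, is how this place would respond to a group carrying an amine or an ether oxygen.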